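The compounds below may be only part of what the source reports. "The series", "measured", "known", "first", "only" and "open" are said of these compounds alone.

Measured so far in a functional assay on PC-3 cells (Homo sapiens) for antiproliferative activity, read by MTT assay; on this read-out lower numbers stand for stronger inhibition and higher numbers for weaker inhibition:

compound 1 `Cn1c(=O)c(=O)n(C2CCCC2)c2nc(N/N=C/c3ccc(F)c(Cl)c3)ncc21`: 8550 nM
compound 2 `Cn1c(=O)c(=O)n(C2CCCC2)c2nc(N/N=C/c3ccc(S(C)(=O)=O)cc3)ncc21`: 26600 nM
compound 3 `Cn1c(=O)c(=O)n(C2CCCC2)c2nc(N/N=C/c3cccc(Cl)c3Cl)ncc21`: 17200 nM

All three share one core and differ only in the aromatic ring attached to a carbon with a double bond to nitrogen. Compound 3 has the second highest of the three numbers. Its nearest neighbour is compound 2, with a 1.5-fold lower number from compound 2 to compound 3 (0.19 log units; within the scatter); its furthest is compound 1, with a 2.0-fold higher number from compound 1 to compound 3 (0.30 log units; within the scatter). Neither of these two gaps stands out from the noise of the measurement, so compound 3 cannot be set apart from either.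

The next compound, compound 4 `COc1ccc(/C=N/Nc2ncc3c(n2)n(C2CCCC2)c(=O)c(=O)n3C)cc1`, changes the same ring again: 4-methoxyphenyl in place of 2,3-dichlorophenyl on a carbon with a double bond to nitrogen.

Three earlier exchanges of this ring bear on the step. The largest was a 3.1-fold higher number from compound 1 to compound 2 (0.49 log units; beyond the scatter), a modest shift. The other two, a 2.0-fold higher number from compound 1 to compound 3 (0.30 log units; within the scatter) and a 1.5-fold lower number from compound 2 to compound 3 (0.19 log units; within the scatter), stayed within the scatter. Exchanging this ring has therefore moved the read-out in this assay only a little, and no case of a 4-methoxyphenyl ring has been measured. A small step, in either direction or none beyond the scatter, is expected for compound 4, which is taken as a 1.2-fold higher number from compound 3 to compound 4 (0.07 log units; within the scatter).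

Compound 4 is therefore estimated at 20000 nM in this assay, within a range from 8000 nM to 50000 nM.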

Compound 4, half-maximal inhibitory concentration: 26300 nM
The estimate for compound 4 lay 1.3-fold (0.12 log units) below the measured number; low and high end bracket the measured number.
By their numbers in this assay, from the lowest: compounds 1, 3, 4 and 2 (each within the scatter of the next, the first and the last beyond it).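

In this assay the exchange of 2,3-dichlorophenyl for 4-methoxyphenyl gives a 1.5-fold higher number from compound 3 to compound 4 (0.18 log units; within the scatter) and so stays inside the usual scatter, which means that two rings with quite different groups cannot be told apart at this position. Methoxy in place of methylsulfonyl on the aromatic carbon gives a 1.0-fold lower number from compound 2 to compound 4 (0.00 log units; within the scatter) with no measurable difference, while a 3.1-fold higher number from compound 1 to compound 4 (0.49 log units; beyond the scatter) matches in size the one earlier step beyond the scatter, so compound 1 now stands apart from both compound 2 and compound 4, though still not from compound 3. No measurement that could explain these steps accompanies the numbers.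

Going by these compounds, all four rings are benzene-type rings carrying chlorine, fluorine, methoxy or methylsulfonyl, so it remains open whether an amine or a carboxylic acid on the ring would shift the read-out further than these groups have. Equally open, on these data alone, are an unsubstituted phenyl ring, which would show what the groups on the ring contribute at all, and a pyridine ring, with nitrogen in the ring itself.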